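Swapping the Pyrrolidinyl Amide for an Acetamido Group

The source may report more compounds than this note shows. Statements on the series, on what has been measured and on what is new or still open speak of the compounds shown alone.

Of the compounds shown here, three built on one shared core have been tested in an assay on COS-7 cells for inhibition of patatin-like phospholipase domain-containing protein 2 (Mus musculus), tested at 200 uM; on this read-out lower numbers stand for less inhibition and higher numbers for more inhibition at the one concentration tested (going by the name of the read-out). Compound 1 `CCOc1ccc(-c2cccc(S(=O)(=O)N(C)C)c2)cc1` gives 63%. Compound 2 `CCOc1ccc(-c2cccc(C)c2)cc1` gives 54% in this assay, and compound 3 `CCOc1ccc(-c2cccc(C(=O)N3CCCC3)c2)cc1` gives 53%. The steps separating these three are a number 9 percentage points lower from compound 1 to compound 2 (within the scatter), a number 10 percentage points lower from compound 1 to compound 3 (within the scatter) and a number 1 percentage points lower from compound 2 to compound 3 (within the scatter); none of them reaches beyond the scatter, so compound 3 cannot be set apart from the other two, and its number sits within the usual spread of both.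

Compound 4 `CCOc1ccc(-c2cccc(NC(C)=O)c2)cc1` differs from compound 3 in a single place: acetamido in place of (pyrrolidin-1-yl)carbonyl on an aromatic carbon. The measured steps that bear on this change are the ones that alter the same aromatic carbon, namely a number 10 percentage points lower from compound 1 to compound 3 (within the scatter) and a number 1 percentage points lower from compound 2 to compound 3 (within the scatter), each of them within the scatter. On that basis a step of a number 1 percentage points lower from compound 3 to compound 4 (within the scatter) is expected in this assay, which is to say no movement beyond the scatter. Compound 4 is therefore estimated at 52%, with a range from 38% to 66%.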

Compound 4, a percentage reported as inhibition, at one concentration (the size of the read-out at that concentration, not a potency): 52%
Beside the measured number, compound 4's estimate shows no gap at the digits printed; measured number inside the range.
By their numbers in this assay, from the lowest: compounds 4, 3, 2 and 1 (each within the scatter of the next, the first and the last beyond it).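

In this assay, acetamido, which has no ring and carries a hydrogen-bond donor that (pyrrolidin-1-yl)carbonyl lacks, gives a number 1 percentage points lower from compound 3 to compound 4 (within the scatter), and in place of methyl it gives a number 2 percentage points lower from compound 2 to compound 4 (within the scatter), so this aromatic carbon now holds three groups with numbers that cannot be told apart. Against dimethylsulfamoyl, the same group gives a number 11 percentage points lower from compound 1 to compound 4 (beyond the scatter), a modest change and the first step in this set to pass beyond the scatter, although compound 1 remains within the scatter of compound 2 and compound 3. Nothing measured here accounts for this small separation.

Going by these compounds, whether a carboxylic acid, a primary amine or a longer alkyl chain on this carbon would move the number further remains open. The read-out, taken at one concentration, also leaves the potency of all four compounds undefined.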